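The source may hold more compounds than are shown below. What is called first, only, known or untested is meant among the compounds shown, and "the series" means these compounds.

Of the compounds shown here, three sharing one core have been measured in an ADME assay on Vero 76 cells (Chlorocebus sabaeus) for cytotoxicity, read by microscopy; on this read-out lower numbers stand for higher toxicity in this test and higher numbers for lower toxicity in this test. Compound 1 `CC(C)[C@@H](Nc1nc(Cl)nc2c1ncn2[C@H]1[C@H](O)[C@H](O)[C@]2(CCl)C[C@H]12)C1CC1` gives 32000 nM, and compound 3 `CSC[C@@]12C[C@@H]1[C@@H](n1cnc3c(N[C@H](C(C)C)C4CC4)nc(Cl)nc31)[C@H](O)[C@@H]2O` gives 32000 nM, so compound 3 stands level with compound 1. Compound 2 `CC(C)(O)[C@@H](Nc1nc(Cl)nc2c1ncn2[C@H]1[C@H](O)[C@H](O)[C@]2(CO)C[C@H]12)C1CC1` is recorded only as a limit of the assay, > 100000 nM. Compound 2 differs from the other two in more than one place, so it offers no size for a single change.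

The next compound to be tested is compound 4 `CC(C)[C@@H](Nc1nc(Cl)nc2c1ncn2[C@H]1[C@H](O)[C@H](O)[C@]2(CN)C[C@H]12)C1CC1`. It carries amino in place of methylsulfanyl on a saturated chain carbon bound to a saturated ring carbon, which amounts to (methylsulfanyl)methyl giving way to aminomethyl: amino in place of methylsulfanyl on a saturated chain carbon bound to a saturated ring carbon.

Going by the values given here, only one measured step bears on this position, methylsulfanyl in place of chloro at the same place, and it reads no change at the digits printed from compound 1 to compound 3 (within the scatter). That step shows the read-out unmoved by one exchange at this carbon, though amino itself has not been tested there. No step beyond the scatter is therefore expected in this assay, and a drift towards higher numbers cannot be excluded given the limit seen for compound 2. The estimated step is a 1.3-fold higher number from compound 3 to compound 4 (0.10 log units; within the scatter). For compound 4 the expected value is 40000 nM, with an estimated range from 16000 nM to 100000 nM.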

Compound 4, half-maximal cytotoxic concentration: 32000 nM
The estimate for compound 4 lay 1.3-fold (0.10 log units) above the measured number, and the stated range covers the measured number.
By their numbers in this assay, from the lowest: compounds 1, 3 and 4 (each within the scatter of the next). At a limit, above all of these: compound 2.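

In this assay, amino in place of methylsulfanyl on a saturated chain carbon bound to a saturated ring carbon reads as no change at the digits printed from compound 3 to compound 4 (within the scatter). Amino in place of chloro on the same carbon reads as no change at the digits printed from compound 1 to compound 4 (within the scatter). Where the earlier compounds offered a single exchange at this carbon, three groups have now been read there on the shared core, chloro, methylsulfanyl and amino, and the read-out does not separate them, even though amino brings 1 hydrogen-bond donor where methylsulfanyl brings 0.

Compound 2 is recorded only at a limit of the assay, and it differs from the other compounds in more than one place, so no single change can be read from it: the limit of > 100000 nM in this assay, at which 1 of the 4 values shown sits. Going by these compounds, whether a carboxylic acid or a longer chain on this carbon would also stay within the scatter of compound 1 remains open, as does whether any exchange at this carbon moves the read-out at all.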